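Swapping Two Chlorines for Bromine and Hydroxyl

A few compounds are considered here, and "the series" means these few. Any claim that something is new, unique, unknown or untested is made for them only; others in the source may bear on it.

The measured compounds:
compound 1, `COc1ccc(C(=O)/C=C/c2cccc([N+](=O)[O-])c2)c2c1C=CC(C)(C)O2`: 4260 nM
compound 2, `COc1ccc(C(=O)/C=C/c2ccsc2)c2c1C=CC(C)(C)O2`: > 10000 nM (a limit)
compound 3, `COc1ccc(C(=O)/C=C/c2ccc(Cl)c(Cl)c2)c2c1C=CC(C)(C)O2`: 7580 nM

All three share one core and differ only in the aryl group on a double-bonded chain carbon bound to a double-bonded chain carbon. In a functional assay on HT-29 cells (Homo sapiens) for antiproliferative activity, read by MTT assay, with a stated time of 24 h (a lower number here means a stronger inhibitor, a higher number a weaker inhibitor), compound 1 gives 4260 nM. In this assay compound 3 gives 7580 nM, the higher of the two numbers. Compound 2 sits at the limit of > 10000 nM in this assay, at which 1 of the 3 values shown sits. The steps are small: a 1.8-fold higher number from compound 1 to compound 3 (0.25 log units; within the scatter), an at least 1.3-fold lower number from compound 2 to compound 3 (0.12 log units; that floor lies within the scatter), and an at least 2.3-fold higher number from compound 1 to compound 2 (0.37 log units; beyond the scatter).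

Compound 4, `COc1ccc(C(=O)/C=C/c2ccc(O)c(Br)c2)c2c1C=CC(C)(C)O2`, is not yet measured. It differs from compound 3 by 3-bromo-4-hydroxyphenyl in place of 3,4-dichlorophenyl on a double-bonded chain carbon bound to a double-bonded chain carbon. For the measured compounds named here, no measured step involves a hydroxyl, so only the exchange of one aryl group for another can guide the guess, and such exchanges among compounds 1, 2 and 3 moved the number little. The expected step of a 1.1-fold lower number from compound 3 to compound 4 (0.03 log units; within the scatter) is therefore within or barely beyond the scatter. Compound 4 is expected to give about 7000 nM, between 2500 nM and 20000 nM.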

Compound 4, half-maximal inhibitory concentration: > 10000 nM
Compound 4: no number, only a limit; the forecaster's own chance of this, stated with the estimate: 25%; middle value at least 1.4-fold (0.15 log units) from the limit.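

With 3-bromo-4-hydroxyphenyl on a double-bonded chain carbon bound to a double-bonded chain carbon, compound 4 gives a limit and not a number in this assay: the limit of > 10000 nM in this assay, at which 2 of the 4 values shown sit.

Against 3,4-dichlorophenyl, which has no hydrogen-bond donor, the new group gives an at least 1.3-fold higher number from compound 3 to compound 4 (0.12 log units; that floor lies within the scatter), so adding a donor here brings no sign of a stronger inhibitor, though compound 3 and compound 4 cannot be firmly separated. The clearer step is an at least 2.3-fold higher number from compound 1 to compound 4 (0.37 log units; beyond the scatter), while the step from compound 2 to compound 4 cannot be read, as both are limits.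

No compound shown carries the hydroxyl without the bromine, so the share of each in this result stays open. On these data alone, how an amine or a carboxylic acid in their place would read in this assay also stays open.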